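Methyl to trifluoromethyl on the benzyl oxime ether

The compounds below may be only part of what the source reports. "The series", "measured", "known", "first", "only" and "open" are said of these compounds alone.

In a functional assay on NCI-H460 cells (Homo sapiens) for cytotoxicity, read by MTT assay, with a stated time of 2 days (a higher number here means a weaker inhibitor, a lower number a stronger inhibitor), compound 1, with the structure `Cc1ccc(CO/N=C2/C(c3c[nH]c4ccccc34)=Nc3ccccc32)cc1`, gives 29800 nM, the highest of the three numbers recorded. Its nearest neighbour is compound 2, `Cc1ccc(CO/N=C2/C(c3c[nH]c4ccc(F)cc34)=Nc3ccc(F)cc32)cc1`, which gives 12000 nM; the furthest is compound 3, `Cc1ccc(CO/N=C2/C(c3c[nH]c4ccc(Br)cc34)=Nc3ccc(Br)cc32)cc1`, with 10600 nM. Going by the values given here, both of those compounds differ from compound 1 in more than one place, so no single step between measured compounds is available, and their values can only be read as they stand.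

The compound not yet measured is compound 4, `FC(F)(F)c1ccc(CO/N=C2/C(c3c[nH]c4ccccc34)=Nc3ccccc32)cc1`. It differs from compound 1 by trifluoromethyl in place of methyl on an aromatic carbon, on an aromatic carbon of a six-membered aromatic ring of carbon only, para to a large group, so that 4-methylphenyl becomes 4-(trifluoromethyl)phenyl. Nothing among the three measured compounds tests this change directly. The step of a 1.5-fold lower number from compound 1 to compound 4 (0.17 log units; within the scatter) is therefore expected to be small, most likely no larger than the usual scatter, with a slight lean toward a lower number. For compound 4 the estimate is 20000 nM, within a range from 7000 nM to 60000 nM.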

Compound 4, half-maximal inhibitory concentration: 24100 nM
The estimate for compound 4 lay 1.2-fold (0.08 log units) below the measured number, within the range that was stated.
By their numbers in this assay, from the lowest: compounds 3, 2, 4 and 1 (each within the scatter of the next, the first and the last beyond it).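

In this assay, going by these compounds alone, trifluoromethyl in place of methyl on an aromatic carbon gives a 1.2-fold lower number from compound 1 to compound 4 (0.09 log units; within the scatter), the first single-place comparison in this set and the first to touch the 4-methylphenyl group, which stays constant across compounds 1, 2 and 3. At this position, then, the exchange of one heavy atom for four leaves the number indistinguishable from that of compound 1, so this change offers no measurable gain or loss in cytotoxicity on these cells. Nothing measured here accounts for this result.

The compounds shown leave open whether an amine, a carboxylic acid or a longer chain at this place would shift the number beyond the scatter. They also leave open whether trifluoromethyl would read the same way on the fluorine-bearing or bromine-bearing cores of compound 2 and compound 3.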